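Shifting the aryl substituent on the oxadiazole-bearing side chain

The compounds below may be only part of what the source reports. "The series", "measured", "known", "first", "only" and "open" are said of these compounds alone.

Of the compounds shown here, three sharing one core have been measured in a functional assay on mitochondria from heart for inhibition of peroxisomal acyl-coenzyme A oxidase 1 (Rattus norvegicus); a lower number here means a stronger inhibitor, a higher number a weaker inhibitor. Compound 1 `Cc1nc2cc(OC[C@H](O)CN3CCN(Cc4noc(-c5ccc(C(F)(F)F)cc5)n4)CC3)ccc2s1` gives 380 nM, the lowest of the three numbers. Compound 2 `Cc1nc2cc(OC[C@H](O)CN3CCN(Cc4nnc(-c5ccc(C(C)(C)C)cc5)o4)CC3)ccc2s1` gives 1100 nM, and compound 3 `Cc1nc2cc(OC[C@H](O)CN3CCN(Cc4csc(-c5ccc(C(F)(F)F)cc5)n4)CC3)ccc2s1` gives 1300 nM; both gaps to compound 1 lie beyond the scatter, so compound 1 is the strongest inhibitor among the three. Compound 4 `Cc1nc2cc(OC[C@H](O)CN3CCN(Cc4noc(-c5cccc(C#N)c5)n4)CC3)ccc2s1` differs from compound 1 in one place: 3-cyanophenyl in place of 4-(trifluoromethyl)phenyl on an aromatic carbon. Among the compounds with values here, no measured pair shows this change, so its effect cannot be read off from existing data. Compound 4 is expected to be a somewhat weaker inhibitor, the step of a 2.1-fold higher number from compound 1 to compound 4 (0.32 log units; beyond the scatter) being a moderate rise in this assay. The value of compound 4 is estimated at 800 nM, within a range of 250 nM to 2500 nM.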

Compound 4, half-maximal inhibitory concentration: 13400 nM
The estimate for compound 4 lay 17-fold (1.22 log units) below the measured number; measured number outside the range, above it.
By their numbers in this assay, from the lowest: compound 1; then compounds 2 and 3 (each within the scatter of the next); then compound 4.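

In this assay the aryl group on this aromatic carbon proves far from interchangeable: 3-cyanophenyl in place of 4-(trifluoromethyl)phenyl brings a 35-fold higher number from compound 1 to compound 4 (1.55 log units; beyond the scatter) and leaves compound 4 with the highest number of the four. No measurement at hand accounts for this loss. The compounds shown leave open whether the step belongs to the nitrile, to the departure of trifluoromethyl, or to the group's place on the phenyl ring, as these change together. From the compounds shown here alone, how an unsubstituted phenyl, or a phenyl carrying a methoxy group or an amine, would read also remains open.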